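A fluoro swap on a well-tolerated compound

A few compounds are considered here, and "the series" means these few. Any claim that something is new, unique, unknown or untested is made for them only; others in the source may bear on it.

In an ADME assay on HepG2 2.2.15 cells (Homo sapiens) for cytotoxicity, read by MTT assay (a lower number here means that less compound is tolerated, a higher number that more compound is tolerated), compound 1 (`CC(=O)c1ccc(OC(=O)c2cccnc2)cc1`) gives 3010000 nM as a measured number. For compound 2 (`COc1cccc(/C=C/C(=O)OC[C@H]2O[C@@H](Oc3ccc(C(C)=O)cc3)[C@H](O)[C@@H](O)[C@@H]2O)c1`) the reading > 1510000 nM is a limit and not a number. Compound 3 (`CC(=O)c1ccc(O[C@@H]2O[C@H](COC(=O)/C=C/c3cccc(F)c3)[C@@H](O)[C@H](O)[C@H]2O)cc1`) differs from compound 2 in one place (fluoro in place of methoxy on an aromatic carbon), with fluoro in place of methoxy on an aromatic carbon. Among the measured compounds shown here, no measured step shows what this change does, so no shift beyond the usual scatter is expected in this assay for this pair. The estimate means a step that the limit leaves unreadable from compound 2 to compound 3 that is expected to stay small. Compound 3 is expected to read 1900000 nM with a range from 800000 nM to 4000000 nM on this estimate.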

Compound 3, half-maximal cytotoxic concentration: 828000 nM
Compound 3: the middle estimate sits 2.3-fold (0.36 log units) above what was measured; the measured number falls inside the stated range.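

Among the compounds shown here, this is the first step at this position on the ring in this assay: fluoro in place of methoxy gives an at least 1.8-fold lower number from compound 2 to compound 3 (0.26 log units; that floor lies within the scatter). Since that floor does not go beyond the usual scatter, the step alone does not establish a real change. The reading for compound 2 is a limit and not a number, which leaves the full size of the step unread: the limit of > 1510000 nM in this assay, at which 1 of the 3 values shown sits.

Still open, as far as these compounds go, is how an amine or a carboxylic acid on this aromatic carbon would read. Also open, from the compounds shown here alone, is whether a plain hydrogen there would read closer to compound 2 or compound 3.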